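A few compounds are considered here, and "the series" means these few. Any claim that something is new, unique, unknown or untested is made for them only; others in the source may bear on it.

Measured so far:
- compound 1 `CN1CCN(CCNCc2cn(-c3ccc(F)cc3F)nc2-c2ccc(S(=O)(=O)N(C)C)cc2)CC1`; in an ADME assay on Huh-7 cells (Homo sapiens) for cytotoxicity (a lower number here means that less compound is tolerated, a higher number that more compound is tolerated), compound 1 gives > 20000 nM, which is a limit of the assay and not a number.
- compound 2 `Cc1ccccc1-c1nn(-c2ccc(F)c(F)c2)cc1CNCCN1CCN(C)CC1`; in this assay compound 2 gives > 20000 nM, likewise a limit of the assay rather than a number.

Compound 2 therefore stands at the ceiling of what has been shown so far, (the limit of > 20000 nM in this assay, at which 2 of the 2 values shown sit). Going by the values given here, no step between measured compounds can be drawn from two limits; the values show only that neither compound was cytotoxic within the tested range. Compound 3 `Cc1ccccc1-c1nn(Cc2ccccc2)cc1CNCCN1CCN(C)CC1` differs from compound 2 by benzyl in place of 3,4-difluorophenyl on an aromatic nitrogen.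

With every shown value sitting at the limit, the expected step in this assay is a step that the limit leaves unreadable from compound 2 to compound 3, none beyond the scatter, and the read-out is expected most likely to be a limit again. Compound 3 is estimated at 25000 nM, within 12000 nM to 60000 nM.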

Compound 3, half-maximal cytotoxic concentration: > 20000 nM
Compound 3: only a limit was reported; the forecaster's own chance of this, stated with the estimate: 80%; the middle value is on the limit's open side.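

No step can be read between compound 2 and compound 3 in this assay, since both results are limits of the assay: the limit of > 20000 nM in this assay, at which 3 of the 3 values shown sit.

Left open is whether benzyl and 3,4-difluorophenyl on an aromatic nitrogen differ in this assay, and at what concentration any of these compounds turns cytotoxic.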